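This account rests on a few compounds, and the source may have more. Where it says the series, first, only, none or still open, it means among the compounds named here.

Three compounds share one core and differ only in the groups carried on the aromatic ring. Compound 1 `CS(=O)(=O)c1cc(F)ccc1NCC1=NCCN1` gives 661 nM in an assay for binding affinity to Alpha-1A adrenergic receptor (Homo sapiens), read by radioligand binding; a higher number here means a weaker inhibitor, a lower number a stronger inhibitor. Compound 2 `CS(=O)(=O)c1ccc(Cl)cc1NCC1=NCCN1` gives 537 nM in this assay, and compound 3 `CS(=O)(=O)c1c(F)cccc1NCC1=NCCN1` gives 550 nM in this assay. Compound 2 has the lowest of the three numbers, yet its gap to compound 3 and its gap to compound 1 both lie within the scatter, so no order among the three can be read from these values.

Compound 4 `COc1ccc(S(C)(=O)=O)c(NCC2=NCCN2)c1` has not yet been measured in this assay. It differs from compound 2 in one place: methoxy in place of chloro on an aromatic carbon. Going by the values given here, no step between measured compounds is available to calibrate this change, and the three measured values sit close together whatever halogen is present and wherever it sits. The step of a 1.3-fold higher number from compound 2 to compound 4 (0.12 log units; within the scatter) is therefore expected to be small, most likely not beyond the scatter, with at most a slight lean toward a higher number. For compound 4 the estimate in this assay is 700 nM, within a range from 300 nM to 1600 nM.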

Compound 4, inhibition constant: 1620 nM
Compound 4: middle estimate off by 2.3-fold (0.36 log units), on the low side; measured number outside the range, above it.
By their numbers in this assay, from the lowest: compounds 2, 3 and 1 (each within the scatter of the next); then compound 4.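

Methoxy in place of chloro on this aromatic carbon, para to a methylsulfonyl group, gives a 3.0-fold higher number from compound 2 to compound 4 (0.48 log units; beyond the scatter) in this assay. This shows that the number in this assay can respond to the group at this position, something the three halogen-bearing compounds, all within the scatter of one another, could not show. Nothing in the data shown accounts for the step.

On these data alone, whether the higher number comes from the arrival of methoxy or the loss of chloro stays open, as this is a single step at a single position. The compounds shown also do not tell how an amine, a hydroxy group or a longer alkoxy chain would compare here, or whether methoxy would give a step of similar size on another aromatic carbon.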